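The source may report more compounds than this note shows. Statements on the series, on what has been measured and on what is new or still open speak of the compounds shown alone.

Compound 1 `CCC(=O)N(C)c1ccc2[nH]c(-c3n[nH]c4ccccc34)cc2n1` gives 15700 nM in a functional assay on A549 cells (Homo sapiens) for antiproliferative activity, read by MTT assay, with a stated time of 72 h; on this read-out higher numbers stand for weaker inhibition and lower numbers for stronger inhibition; compound 2 `CN(C(=O)CCc1ccccc1)c1ccc2[nH]c(-c3n[nH]c4ccccc34)cc2n1` gives 18100 nM; compound 3 `CN(C(=O)c1ccc(Br)cc1)c1ccc2[nH]c(-c3n[nH]c4ccccc34)cc2n1` gives 4250 nM.

Compound 2 holds the highest number of the three: there is a 1.2-fold higher number from compound 1 to compound 2 (0.06 log units; within the scatter), and there is a 4.3-fold lower number from compound 2 to compound 3 (0.63 log units; beyond the scatter). Compound 4 `COc1ccc(C(=O)N(C)c2ccc3[nH]c(-c4n[nH]c5ccccc45)cc3n2)cc1` differs from compound 2 by 4-methoxyphenyl in place of phenethyl on a carbonyl carbon. For the measured compounds named here, two measured steps bear on this change, each swapping a chain for a ring on the carbonyl carbon: a 4.3-fold lower number from compound 2 to compound 3 (0.63 log units; beyond the scatter) and a 3.7-fold lower number from compound 1 to compound 3 (0.57 log units; beyond the scatter). On that basis a step in the same direction, of modest size, is expected in this assay, namely a 3.0-fold lower number from compound 2 to compound 4 (0.48 log units; beyond the scatter). Compound 4 is therefore estimated at 6000 nM, with a range from 2500 nM to 15000 nM.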

Compound 4, half-maximal inhibitory concentration: 14600 nM
Beside the measured number, compound 4's estimate is 2.4-fold (0.39 log units) below it, within the range that was stated.
By their numbers in this assay, from the lowest: compound 3; then compounds 4, 1 and 2 (each within the scatter of the next).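

Swapping a chain for a ring on the carbonyl carbon does not by itself change the number: 4-methoxyphenyl in place of phenethyl gives (a 1.2-fold lower number from compound 2 to compound 4 (0.09 log units; within the scatter)) and 4-methoxyphenyl in place of ethyl gives (a 1.1-fold lower number from compound 1 to compound 4 (0.03 log units; within the scatter)). The separation of compound 3 from the other three instead tracks the group on the ring, as methoxy in place of bromo on an aromatic carbon gives (a 3.4-fold higher number from compound 3 to compound 4 (0.54 log units; beyond the scatter)). No measurement shown gives a reason for this. As far as these compounds go, it remains open whether chloro, an amine or a carboxylic acid in that place would behave like bromo or like methoxy, and where plain phenyl on the carbonyl carbon would stand.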